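This account rests on a few compounds, and the source may have more. Where it says the series, first, only, none or still open, it means among the compounds named here.

Within the data shown here, compound 2 `CN(CCN1CCCCC1)c1ccc(C(=O)N2CCc3ccc(OS(N)(=O)=O)cc3C2)cc1` gives 0.3% in an assay on HEK293 cells for inhibition of Steryl-sulfatase (Homo sapiens), tested at 0.1 uM (a higher number here means a stronger effect of the compound at the concentration tested, a lower number a weaker effect), the lowest of the two numbers measured so far. Among the measured compounds shown here, the only neighbour is compound 1 `CCN(Cc1ccncc1)c1ccc(C(=O)N2CCc3ccc(OS(N)(=O)=O)cc3C2)cc1`, which gives 47% in this assay. For the measured compounds named here, the single measured step is a number 46.7 percentage points lower from compound 1 to compound 2 (beyond the scatter), a swap of the amino substituent on the same core. Compound 3 `CCCN(CCC)c1ccc(C(=O)N2CCc3ccc(OS(N)(=O)=O)cc3C2)cc1` differs from compound 2 in the same position: dipropylamino in place of methyl(2-(piperidin-1-yl)ethyl)amino on an aromatic carbon. Going by the values given here, that one step is the only guide, and it was large, so a rise beyond the scatter is expected, a number 24.7 percentage points higher from compound 2 to compound 3 (beyond the scatter). Compound 3 is accordingly estimated at 25%, within 0% to 60%.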

Compound 3, a percentage reported as inhibition, at one concentration (the size of the read-out at that concentration, not a potency): 36.6%
Compound 3: the middle estimate sits 11.6 percentage points below what was measured; the range from low to high includes it.
By their numbers in this assay, from the lowest: compound 2; then compound 3; then compound 1.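

Exchanging methyl(2-(piperidin-1-yl)ethyl)amino for dipropylamino recovers much of the read-out in this assay (a number 36.3 percentage points higher from compound 2 to compound 3 (beyond the scatter)), so this position accepts a group with no ring and keeps a clear effect. The ring-bearing ethyl((pyridin-4-yl)methyl)amino group still stands ahead of dipropylamino (a number 10.4 percentage points lower from compound 1 to compound 3 (beyond the scatter)), so of the two ring-bearing groups only the piperidine one goes with the near-complete loss. No measured evidence accounts for this order.

Open, as far as these compounds go, is whether the loss follows the piperidine ring itself or its ethyl linker. A morpholine on the same ethyl linker, or a longer chain such as dibutylamino, would separate these readings.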